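Compound 4: an isomer of compound 3 awaiting measurement

This account rests on a few compounds, and the source may have more. Where it says the series, first, only, none or still open, it means among the compounds named here.

Of the compounds shown here, three sharing one core have been measured in a functional assay on HUVEC cells (Homo sapiens), read by scintillation counting and thymidine incorporation, with a stated time of 24 h (a lower number here means a stronger inhibitor, a higher number a weaker inhibitor), and they differ only in the group on a saturated chain carbon bound to a saturated ring carbon. Compound 1 `CCC(C)n1ncn(-c2ccc(N3CCN(c4ccc(OC[C@@H]5CO[C@@](CBr)(c6ccc(Cl)cc6Cl)O5)cc4)CC3)cc2)c1=O`, which carries bromo, gives 569 nM. Compound 2 `CCC(C)n1ncn(-c2ccc(N3CCN(c4ccc(OC[C@@H]5CO[C@@](CN(C)C)(c6ccc(Cl)cc6Cl)O5)cc4)CC3)cc2)c1=O`, which carries dimethylamino, gives 1400 nM. Compound 3 `CCC(C)n1ncn(-c2ccc(N3CCN(c4ccc(OC[C@@H]5CO[C@@](Cn6cc(C)nc6C)(c6ccc(Cl)cc6Cl)O5)cc4)CC3)cc2)c1=O`, which carries 2,4-dimethyl-1H-imidazol-1-yl, gives 492 nM. That places the 2,4-dimethyl member level with the bromo member, at a 1.2-fold lower number from compound 1 to compound 3 (0.06 log units; within the scatter), and apart from the dimethylamino member, at a 2.8-fold lower number from compound 2 to compound 3 (0.45 log units; beyond the scatter).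

Going by the values given here, compound 4 `CCC(C)n1ncn(-c2ccc(N3CCN(c4ccc(OC[C@@H]5CO[C@@](Cn6c(C)cnc6C)(c6ccc(Cl)cc6Cl)O5)cc4)CC3)cc2)c1=O` changes only this group: 2,5-dimethyl-1H-imidazol-1-yl in place of 2,4-dimethyl-1H-imidazol-1-yl on a saturated chain carbon bound to a saturated ring carbon. It has 2,5-dimethyl-1H-imidazol-1-yl in place of 2,4-dimethyl-1H-imidazol-1-yl, with the same atoms joined differently. Among the compounds with values here, no measured step shows an exchange of this kind, so the evidence is indirect. The exchanges of whole groups at this place were all small, the largest being a 2.8-fold lower number from compound 2 to compound 3 (0.45 log units; beyond the scatter), while the other two were a 2.5-fold higher number from compound 1 to compound 2 (0.39 log units; beyond the scatter) and a 1.2-fold lower number from compound 1 to compound 3 (0.06 log units; within the scatter). A change between two isomers is therefore expected to stay within the scatter, and the data favour no direction. The estimated step is a 1.0-fold higher number from compound 3 to compound 4 (0.01 log units; within the scatter). Compound 4 is expected at 500 nM, with an estimated range of 240 nM to 1000 nM.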

Compound 4, half-maximal inhibitory concentration: 765 nM
Compound 4: the middle estimate sits 1.5-fold (0.18 log units) below what was measured; measured number inside the range.
By their numbers in this assay, from the lowest: compounds 3, 1, 4 and 2 (each within the scatter of the next, the first and the last beyond it).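

In this assay, putting 2,5-dimethyl-1H-imidazol-1-yl in place of its isomer 2,4-dimethyl-1H-imidazol-1-yl gives a 1.6-fold higher number from compound 3 to compound 4 (0.19 log units; within the scatter) and so stays within the scatter, which shows for this one pair that the same atoms joined differently on a saturated chain carbon bound to a saturated ring carbon leave no separable difference. The bromo member also stays level with the new isomer, at a 1.3-fold higher number from compound 1 to compound 4 (0.13 log units; within the scatter) and again within the scatter, whereas the step to the dimethylamino member, a 1.8-fold lower number from compound 2 to compound 4 (0.26 log units; within the scatter), does not clear the scatter as the corresponding step to compound 3 did, so the separation of the dimethylamino member holds for only one of the two imidazole isomers. Nothing available here accounts for these readings.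

This single isomer pair cannot say how the number would respond to an imidazol-1-yl group with no methyl groups, or to one with a single methyl group. Going by these compounds, whether a 1,2,4-triazol-1-yl or a morpholine group at this place would stay level with compound 3 and compound 4 also remains open.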